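The source may report more compounds than this note shows. Statements on the series, on what has been measured and on what is new or still open speak of the compounds shown alone.

Compound 2 `Clc1ncnc2sc(Nc3cccc(Br)c3)nc12` gives 12600 nM in an assay on CHO cells for displacement of a labelled ligand from adenosine receptor A1 (Homo sapiens), read by scintillation counting, with a stated time of 3 h; a lower number here means a stronger inhibitor, a higher number a weaker inhibitor. Compound 1 `Clc1ccc(Nc2nc3c(N4CCCC4)ncnc3s2)cc1` gives > 100000 nM in this assay, a limit of the assay. Compound 3 `Clc1ncnc2sc(Nc3ccccc3)nc12` gives > 100000 nM in this assay, likewise a limit.

For the measured compounds named here, compound 2 thus stands as the only compound with a number in this assay; the other two values are limits, and the limit of > 100000 nM in this assay, at which 2 of the 3 values shown sit, is where they sit. Going by the values given here, the one step that can be measured is an at least 7.9-fold higher number from compound 2 to compound 3 (0.89 log units; beyond the scatter), so removing the bromo costs at least a modest amount of binding.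

Compound 4 `OC[C@@H]1CCCN1c1ncnc2sc(Nc3cccc(Br)c3)nc12` carries the change (2-(hydroxymethyl)pyrrolidin-1-yl in place of chloro on an aromatic carbon). Among the compounds with values here, no measured step covers this change. Compound 1 carries a plain pyrrolidin-1-yl group at the same position but a different aryl group, and in this assay compound 1 gives > 100000 nM, a limit of the assay; because compound 2 and compound 3 differ by an at least 7.9-fold higher number from compound 2 to compound 3 (0.89 log units; beyond the scatter), the aryl group alone could account for that limit, so compound 1 says little about the pyrrolidine itself. The direction of the step for compound 4 is therefore open, and the expectation is a step of about a 1.3-fold lower number from compound 2 to compound 4 (0.10 log units; within the scatter), within the scatter. Compound 4 is expected to give about 10000 nM in this assay, with a wide range from 1000 nM to 100000 nM.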

Compound 4, inhibition constant: 530 nM
Compound 4: middle estimate off by 19-fold (1.28 log units), on the high side; measured number outside the range, below it.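

For the compounds shown here, putting 2-(hydroxymethyl)pyrrolidin-1-yl in place of chloro on the aromatic carbon next to the ring nitrogen gives a 24-fold lower number from compound 2 to compound 4 (1.38 log units; beyond the scatter) in this assay and so brings the first measured change at this position. The earlier step spoke only of the bromo on the aryl group, whereas this one shows that the position next to the ring nitrogen also moves the number strongly, with the bromo held constant. It also shows that chloro is not needed there for binding, and that the larger group entering at this carbon, with its hydroxyl and its defined stereocentre, is accepted and gives the lower number.

As far as these compounds go, whether the gain belongs to the pyrrolidine ring, the hydroxymethyl arm or the stereocentre stays open, and a plain pyrrolidin-1-yl, a methoxymethyl group, the mirror-image stereocentre or an open-chain amine such as dimethylamino on the bromo-bearing compound would separate these. Whether the bromo still counts for as much with this new group in place also stays open, and no further step to compound 4 can be read: the limit of > 100000 nM in this assay, at which 2 of the 4 values shown sit.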